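A few compounds are considered here, and "the series" means these few. Any claim that something is new, unique, unknown or untested is made for them only; others in the source may bear on it.

Compound 1 `CC(C)(C)c1cc(NC(=O)Nc2ccc(Nc3ncnc4c3OCCN4)cc2)no1` is the reference point of the series. Among the compounds with values here, in an assay on isolated protein for inhibition of proto-oncogene tyrosine-protein kinase receptor Ret (Homo sapiens), read by 33P incorporation, with stated times of 15 min and 40 min (a higher number here means a weaker inhibitor, a lower number a stronger inhibitor), compound 1 gives 10 nM, the lowest of the two numbers measured so far. Within the data shown here, its only measured neighbour is compound 2 `CC(C)(C)c1csc(NC(=O)Nc2ccc(Nc3ncnc4c3OCCN4)cc2)n1`, which in this assay gives 3150 nM. Among the measured compounds shown here, the single recorded step, a 320-fold higher number from compound 1 to compound 2 (2.50 log units; beyond the scatter), exchanges the heteroaryl on the urea nitrogen and moves the number far beyond the scatter; it is the only information on the series, and it concerns a position remote from the central ring that carries the two aniline nitrogens.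

Compound 3 `CC(C)(C)c1cc(NC(=O)Nc2ccc(Nc3ncnc4c3OCCN4)c(F)c2)no1` is not yet measured. It differs from compound 1 by fluoro in place of hydrogen on an aromatic carbon, a single fluorine on an aromatic carbon of a six-membered aromatic ring of carbon only, ortho to a large group and meta to a large group, with the heteroaryl of compound 1 retained. For the measured compounds named here, no measured step bears on a change at this ring, so the step from compound 1 to compound 2 gives no guide, and a change within the scatter is the working assumption. For compound 3 a step of a 1.2-fold higher number from compound 1 to compound 3 (0.08 log units; within the scatter) is expected. Compound 3 is therefore estimated at 12 nM, with a range from 4 nM to 35 nM.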

Compound 3, half-maximal inhibitory concentration: 21 nM
Compound 3: middle estimate off by 1.8-fold (0.24 log units), on the low side; low and high end bracket the measured number.
By their numbers in this assay, from the lowest: compound 1; then compound 3; then compound 2.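

The six-membered aromatic ring of carbon only now has a measured step of its own: in this assay, fluoro in place of hydrogen on an aromatic carbon ortho to a large group and meta to a large group gives a 2.1-fold higher number from compound 1 to compound 3 (0.32 log units; beyond the scatter). This position therefore responds to the addition of a single fluorine, and the modest step lies beyond the scatter. The change is much smaller than the exchange at the amide-type nitrogen, a 320-fold higher number from compound 1 to compound 2 (2.50 log units; beyond the scatter), so the series now shows one large step at that nitrogen and one modest step at this ring. No measurement here bears on why this fluorine raises the number.

On these data alone, whether chloro, methyl or methoxy on the same aromatic carbon would give a step of similar size remains open, as does the effect of fluoro on the other carbons of this ring. Also open, as far as these compounds go, is whether the fluoro step would carry over to the 4-(tert-butyl)-1,3-thiazol-2-yl series, since it has been read only with the 5-(tert-butyl)-1,2-oxazol-3-yl group in place.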